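A few compounds are considered here, and "the series" means these few. Any claim that something is new, unique, unknown or untested is made for them only; others in the source may bear on it.

Of the compounds shown here, three have been measured so far in a functional assay on SGC-7901 cells (Homo sapiens) for cytotoxicity, read by MTT assay, with a stated time of 48 h; a higher number here means a weaker inhibitor, a lower number a stronger inhibitor. Compound 1 `CCCCSCC(=O)N1N=C(c2cc3ccccc3oc2=O)C[C@@H]1c1ccccc1` gives 7300 nM, compound 2 `O=C(CSc1ncccn1)N1N=C(c2cc3ccccc3oc2=O)C[C@@H]1c1ccc(C(F)(F)F)cc1` gives 4390 nM, and compound 3 `O=C(CSCc1ccco1)N1N=C(c2cc3ccccc3oc2=O)C[C@@H]1c1ccc(C(F)(F)F)cc1` gives 9740 nM. On these numbers compound 3 cannot be told apart from compound 1, while its number is clearly higher, and so weaker, than that of compound 2.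

The next structure, compound 4 `CCCCSCC(=O)N1N=C(c2cc3ccccc3oc2=O)C[C@@H]1c1ccc(C(F)(F)F)cc1`, alters compound 3 in one place: propyl in place of furan-2-yl on a saturated chain carbon bound to a sulfur. In other words, (furan-2-yl)methyl becomes butyl on the sulfur. Going by the values given here, only one measured step touches the same part of the molecule: a 2.2-fold higher number from compound 2 to compound 3 (0.35 log units; beyond the scatter). That modest step, from pyrimidin-2-yl to (furan-2-yl)methyl on a sulfur, shows that a swap here can register, though only just beyond the scatter.

Without the trifluoromethyl group that compound 3 has, compound 1 already carries butylsulfanyl, and compound 1 stands at 7300 nM, within the scatter of compound 3. In this assay no step beyond the scatter is therefore expected, with a slight lean towards a lower number. The expected change is a 1.5-fold lower number from compound 3 to compound 4 (0.18 log units; within the scatter). For compound 4 the estimated value is 6500 nM, with an expected range from 2800 nM to 14000 nM.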

Compound 4, half-maximal inhibitory concentration: 2910 nM
For compound 4 the middle estimate is 2.2-fold (0.35 log units) above the measured one; measured number inside the range.
By their numbers in this assay, from the lowest: compounds 4, 2, 1 and 3 (each within the scatter of the next, the first and the last beyond it).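

In this assay, butyl on the sulfur outperforms (furan-2-yl)methyl, with a 3.3-fold lower number from compound 3 to compound 4 (0.52 log units; beyond the scatter), so at this position a plain chain with no ring gives the lower number and the furan ring is not needed for activity. Set against pyrimidin-2-yl on the sulfur, butyl gives a 1.5-fold lower number from compound 2 to compound 4 (0.18 log units; within the scatter), so these two groups cannot be told apart here, and among the three groups compared on the sulfur in the trifluoromethyl series, only (furan-2-yl)methyl stands out, with a higher number than either of the others. Going by these compounds alone, this result also opens a second place in the molecule to reading: with butylsulfanyl held constant, trifluoromethyl in place of hydrogen on an aromatic carbon gives a 2.5-fold lower number from compound 1 to compound 4 (0.40 log units; beyond the scatter), the first step to isolate that change.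

Nothing measured here gives a reason for any of these steps. On these data alone, it remains open whether a longer chain than butyl, or an amine at the end of the chain, would keep this level of activity, and whether the trifluoromethyl step would be the same size with a different group on the sulfur.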